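Hydrogen in place of 4-methylpiperidin-1-yl in compound 3

A few compounds are considered here, and "the series" means these few. Any claim that something is new, unique, unknown or untested is made for them only; others in the source may bear on it.

Of the compounds shown here, three have been measured in a functional assay on NCI-H1975 cells (Homo sapiens) for cytotoxicity, read by MTT assay, with a stated time of 72 h; a higher number here means a weaker inhibitor, a lower number a stronger inhibitor. Compound 1 (`CN1CCN(c2ccc(Nc3ncc4nc(Nc5ccccc5)n(C5CCCCC5)c4n3)cc2)CC1`) gives the lowest number (390 nM). Compound 2 (`Cc1cc(C)cc(-n2c(Nc3ccccc3)nc3cnc(Nc4ccc(N5CCN(C)CC5)cc4)nc32)c1`) follows (1910 nM). Compound 3 (`CC1CCN(c2ccc(Nc3ncc4nc(Nc5ccccc5)n(C5CCCC5)c4n3)cc2)CC1`) gives the highest number of the three (9800 nM) and is the weakest inhibitor so far, clearly apart from both others.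

Compound 4 (`c1ccc(Nc2ncc3nc(Nc4ccccc4)n(C4CCCC4)c3n2)cc1`) has hydrogen in place of 4-methylpiperidin-1-yl on an aromatic carbon. The group that leaves is thus replaced by no heavy atom at all.

Among the measured compounds shown here, only one measured step changes a single place (a 4.9-fold higher number from compound 1 to compound 2 (0.69 log units; beyond the scatter)). That modest step replaces cyclohexyl with 3,5-dimethylphenyl on an aromatic nitrogen, so it bears on the present change only as a rough guide to size. Compound 1 and compound 3 differ in more than one place, so their values do not isolate this change. For the measured compounds named here, no measured pair isolates the group that leaves, and the direction is therefore a judgement. A modest further rise in this assay seems the likeliest outcome, with a wide margin on either side.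

The expected step is a higher number (a 2.2-fold higher number from compound 3 to compound 4 (0.35 log units; beyond the scatter)). The estimated value for compound 4 is 22000 nM (expected range 6000 nM to 70000 nM).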

Compound 4, half-maximal inhibitory concentration: > 10000 nM
Compound 4 was reported as a limit (the forecaster's own chance of this, stated with the estimate: 35%); the middle value lies beyond the limit too.
By their numbers in this assay, from the lowest: compound 1; then compound 2; then compound 3. At a limit, above all of these: compound 4.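

In this assay compound 4 is reported only as a limit, > 10000 nM, so the loss of 4-methylpiperidin-1-yl has no measured size. The step reads as an at least 1.0-fold higher number from compound 3 to compound 4 (0.00 log units; that floor lies within the scatter), which fixes a floor and no more, and this floor does not set compound 4 apart from compound 3. The new information is one of direction only: with hydrogen on this aromatic carbon, para to a large group, the limit shows no gain over compound 3, so 4-methylpiperidin-1-yl is not shown to be a liability at this place, and the whole reading rests on one censored entry: the limit of > 10000 nM in this assay, at which 1 of the 4 values shown sits.

From the compounds shown here alone, how much 4-methylpiperidin-1-yl contributes in compound 3 stays open, since any true difference from compound 4 could be small or large. Also open, going by these compounds, is how a morpholine ring or a simple dimethylamino group at the same place would read with the rest of compound 3 held fixed, which would show whether a nitrogen-bearing group here can move the number at all.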